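A few compounds are considered here, and "the series" means these few. Any claim that something is new, unique, unknown or untested is made for them only; others in the source may bear on it.

The study concerns four compounds built on related chromenone cores, each carrying a dithiocarbamate arm and a chlorine, and examined in a functional assay on HeLa cells (Homo sapiens) for antiproliferative activity, read by MTT assay, with a stated time of 72 h; a lower number here means a stronger inhibitor, a higher number a weaker inhibitor.

Compound 1, `O=c1cc(CSC(=S)N2CCCC2)oc2cc(Cl)ccc12`, gives in this assay a value that is a limit of the assay rather than a number, > 40000 nM. Compound 2, `CC(C)N(C(=S)SCc1oc2ccccc2c(=O)c1Cl)C(C)C`, likewise reaches only a limit in this assay, > 40000 nM. Compound 3, `CC(C)N(C(=S)SCc1cc(=O)c2ccc(Cl)cc2o1)C(C)C`, also returns a limit in this assay, > 30000 nM. Compound 4, `O=c1c(Cl)c(CSC(=S)N2CCCC2)oc2ccccc12`, has not yet been measured.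

The change from compound 3 to compound 1 is pyrrolidin-1-yl in place of diisopropylamino on a thiocarbonyl carbon. Because both ends sit at limits, the step that the two limits leave unreadable from compound 3 to compound 1 cannot be read, a situation that rests on the limit of > 30000 nM in this assay, at which 1 of the 3 values shown sits, and (the limit of > 40000 nM in this assay, at which 2 of the 3 values shown sit). The difference between the core of compound 2 and the core of compound 3 is not broken down here.

The same change, (pyrrolidin-1-yl in place of diisopropylamino on a thiocarbonyl carbon), carries compound 2 to compound 4, at the same place on a thiocarbonyl carbon whose other neighbours are sulfur. For the measured compounds named here, since the only measured instance of this change lies between two limits, and the starting point for compound 4 sits at the limit of > 40000 nM in this assay, at which 2 of the 3 values shown sit, the step that the limit leaves unreadable from compound 2 to compound 4 is expected to be no more readable than the earlier one. Compound 4 is therefore estimated to give 50000 nM in this assay, with an expected range from 15000 nM to 200000 nM, and a high chance that only a limit is reported.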

Compound 4, half-maximal inhibitory concentration: 700 nM
Compound 4: the middle estimate sits 71-fold (1.85 log units) above what was measured; the whole stated range lies above it.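

In this assay, pyrrolidin-1-yl in place of diisopropylamino on the core of compound 2 gives an at least 57-fold lower number from compound 2 to compound 4 (1.75 log units; beyond the scatter), a large change beyond the scatter, and its true size remains a lower bound because the starting value is a limit: the limit of > 40000 nM in this assay, at which 2 of the 4 values shown sit.

On the core of compound 3, the same change leads to compound 1, but that step cannot be read because both of its ends are limits: the limit of > 30000 nM in this assay, at which 1 of the 4 values shown sits.

Compound 1 also carries pyrrolidin-1-yl and gives > 40000 nM, which is a limit, so the series shows a readable gain on one core only and does not show that the change carries over from one core to another.

The compounds shown leave open whether the result in compound 4 is particular to pyrrolidin-1-yl, as piperidin-1-yl, morpholin-4-yl and diethylamino do not stand among them on the thiocarbonyl carbon. They also leave open how a bromine or a plain hydrogen in place of the chlorine on the core of compound 4 would read in this assay.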